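The compounds below may be only part of what the source reports. "The series", "measured", "known", "first", "only" and "open" are said of these compounds alone.

Measured in an ADME assay on CEM-SS cells (Homo sapiens) for cytotoxicity, read by XTT assay; a lower number here means that less compound is tolerated, a higher number that more compound is tolerated:

- Compound 1 `CN(O)C(=O)c1cc2c(CO)cn(Cc3ccc(F)cc3)c2cn1`: > 266000 nM, a limit
- Compound 2 `CN(O)C(=O)c1cc2c(COC3CCOCC3)cn(Cc3ccc(F)cc3)c2cn1`: > 100000 nM, a limit
- Compound 3 `CN(O)C(=O)c1cc2c(CCCO)cn(Cc3ccc(F)cc3)c2cn1`: > 10000 nM, a limit

Compound 3 therefore has no exact number, only a limit, and the other two values shown are limits as well. Compound 4 `COCCOCCCc1cn(Cc2ccc(F)cc2)c2cnc(C(=O)N(C)O)cc12` differs from it by 2-methoxyethyl in place of hydrogen on an oxygen on a saturated carbon. The closest measured change is oxan-4-yl in place of hydrogen on an oxygen on a saturated carbon, which gives a step that the two limits leave unreadable from compound 1 to compound 2. The change in the chain itself gives a step that the two limits leave unreadable from compound 1 to compound 3. Neither has a readable size. Given a step that the two limits leave unreadable from compound 1 to compound 2, no change beyond the usual scatter is expected in this assay, in either direction, and the estimated change is a step that the limit leaves unreadable from compound 3 to compound 4. Compound 4 is expected at 40000 nM, with an estimated range of 10000 nM to 150000 nM.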

Compound 4, half-maximal cytotoxic concentration: > 10000 nM
Compound 4 was reported as a limit; the forecaster's own chance of this, stated with the estimate: 85%; the middle value is on the limit's open side.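

Among the compounds shown here, compound 4, like compound 1, compound 2 and compound 3, has only a limit, and no step among them can be read. The compounds shown leave open how much compound the cells actually tolerate and whether any of these changes shifts that amount.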